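A few compounds are considered here, and "the series" means these few. Any claim that something is new, unique, unknown or untested is made for them only; others in the source may bear on it.

Measured compounds:
compound 1, `O=C(COc1cccc2ccccc12)N/N=C/c1ccc(O)cc1`: 20 ug/mL
compound 2, `C/C(=N\NC(=O)COc1cccc2ccccc12)c1cccc([N+](=O)[O-])c1`: 20 ug/mL

In an ADME assay on HEL cells (Homo sapiens) for cytotoxicity (on this read-out higher numbers stand for lower toxicity in this test and lower numbers for higher toxicity in this test), compound 1 gives 20 ug/mL, and compound 2 gives 20 ug/mL. On these numbers compound 1 stands level with compound 2: the two values agree at the digits shown and lie within the usual scatter of each other, so nothing separates them in this test. Both compounds share a core, and compound 3, `O=C(COc1cccc2ccccc12)N/N=C/c1cccc(Cl)c1`, keeps that shared core. Compound 3 differs from compound 1 in one place: 3-chlorophenyl in place of 4-hydroxyphenyl on a carbon with a double bond to nitrogen. Within the data shown here, no pair of measured compounds differs in a single place, so no measured step guides this change; the only guidance is that compound 1 and compound 2 show the same value despite differing structures. A step of no more than the scatter, in either direction, is therefore expected in this assay, and the expected step is no change at the digits printed from compound 1 to compound 3 (within the scatter). Compound 3 is estimated at 20 ug/mL, with a range from 5 ug/mL to 60 ug/mL.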

Compound 3, minimum cytotoxic concentration: 100 ug/mL
Beside the measured number, compound 3's estimate is 5.0-fold (0.70 log units) below it; measured number outside the range, above it.
By their numbers in this assay, from the lowest: compounds 1 and 2 (each within the scatter of the next); then compound 3.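

In this assay, among these compounds, the exchange of 4-hydroxyphenyl for 3-chlorophenyl on a carbon with a double bond to nitrogen gives a 5.0-fold higher number from compound 1 to compound 3 (0.70 log units; beyond the scatter), the first single-place step at this position and one beyond the scatter. The group that leaves carries a hydrogen-bond donor and a hydrogen-bond acceptor and the group that enters carries neither, while both have the same heavy-atom count and a six-membered aromatic ring of carbon only. Nothing shown here accounts for the step.

The compounds shown do not separate the loss of the hydroxy group from the arrival of the chlorine, or either of these from the change in ring numbering. Going by these compounds, how this position would read with an amine, a carboxylic acid or a methoxy group on the phenyl ring also stays open.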